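Amide substitution on a pyrazole anti-inflammatory series

The compounds below may be only part of what the source reports. "The series", "measured", "known", "first", "only" and "open" are said of these compounds alone.

Of the compounds shown here, three sharing one core have been tested in a functional assay on the whole organism (strain Wistar) for inhibition, with Rattus norvegicus as the target, read by paw edema, with stated times of 30 min and 3 h, at a dose of 100 mg/kg by the oral route; a lower number here means less inhibition, a higher number more inhibition at the dose given (going by the name of the read-out). Compound 1 `COc1cc(C(=O)N(C)C)nn1-c1ccccc1` gives 47.5% in this assay. Among the measured compounds shown here, compound 2 `CCCCNC(=O)c1cc(OC)n(-c2ccccc2)n1` gives 20.6%, and the single measured step, a number 26.9 percentage points lower from compound 1 to compound 2 (beyond the scatter), shows the number going down with that change on the carbonyl carbon. Compound 3 `CCCCOc1cc(C(=O)NC)nn1-c1ccccc1` gives 65%, the highest of the three numbers, standing clear of both compound 1 and compound 2 beyond the usual scatter.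

Compound 4 `CCCCOc1cc(C(=O)N2CCCCC2)nn1-c1ccccc1` has not been measured. It differs from compound 3 in one place: piperidin-1-yl in place of methylamino on a carbonyl carbon. For the measured compounds named here, the change runs in the opposite sense to the measured step, turning a secondary amide into a tertiary one; no measured pair exchanges methylamino for piperidin-1-yl directly, so the only guidance comes from the dimethylamino-to-butylamino step. Since that step lowered the number when the tertiary amide was lost, a gain of moderate size is expected here, though compound 3 already starts high and the read-out is a percentage with an upper bound. Compound 4 is therefore estimated at 70% in this assay, with a range from 48% to 88%. The expected step, a number 5 percentage points higher from compound 3 to compound 4 (within the scatter), is modest and upward.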

Compound 4, a percentage reported as inhibition, in the whole organism at one dose (the size of the read-out at that dose, not a potency): 15.6%
Estimate against measurement, compound 4: 54.4 percentage points above; measured number below the stated range.
By their numbers in this assay, from the lowest: compounds 4 and 2 (each within the scatter of the next); then compound 1; then compound 3.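

On the carbonyl carbon of compound 3, piperidin-1-yl in place of methylamino in this assay gives a number 49.4 percentage points lower from compound 3 to compound 4 (beyond the scatter) and so removes most of the read-out seen with the smaller group. The earlier step, a number 26.9 percentage points lower from compound 1 to compound 2 (beyond the scatter), also went down, but it ran the other way, from a group without an amide hydrogen to one with it, so across these two pairs neither the presence nor the absence of that hydrogen goes with a higher number, and the identity of the group on the amide nitrogen matters at this position. Nothing available explains why the number falls with this change.

Going by these compounds, it remains open whether the drop follows the ring itself or simply the larger group, which pyrrolidin-1-yl, morpholin-4-yl or dimethylamino on the carbonyl carbon of the core of compound 3 could help to separate. Each number also comes from a single dose, so how these amides would compare across a range of doses is not known.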